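From a 3-methoxyphenyl amide to a 4-methylbenzyl amide

This account rests on a few compounds, and the source may have more. Where it says the series, first, only, none or still open, it means among the compounds named here.

Measured in a functional assay on A549 cells (Homo sapiens) for inhibition, read by MTT assay, with a stated time of 48 h; a lower number here means a stronger inhibitor, a higher number a weaker inhibitor:
Compound 1 `COc1ccc(CNC(=O)/C=C/c2coc3cc(O)ccc3c2=O)cc1`: > 100000 nM (a limit of the assay, not a number)
Compound 2 `COc1cccc(NC(=O)/C=C/c2coc3cc(OC)ccc3c2=O)c1`: 12800 nM
Compound 3 `COc1ccc(NC(=O)/C=C/c2coc3cc(O)ccc3c2=O)cc1`: 12800 nM

The starting point is compound 2, which gives 12800 nM. Compound 3 gives 12800 nM, so the two stand level at the digits shown and within the usual scatter of this kind of measurement. Neither can be called the better inhibitor.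

The next compound to be tested is compound 4 `COc1ccc2c(=O)c(/C=C/C(=O)NCc3ccc(C)cc3)coc2c1`. It has 4-methylbenzyl in place of 3-methoxyphenyl on an amide-type nitrogen.

For the measured compounds named here, no two measured compounds here differ in one place only, so no measured step can serve as a direct guide. The nearest hint is compound 1, which carries a benzyl-type group on its amide-type nitrogen. In this assay compound 1 gives > 100000 nM, and this is a limit, not a number.

On that single hint, a moderate weakening is expected in this assay, with higher numbers meaning weaker inhibition. The expected change is a 2.3-fold higher number from compound 2 to compound 4 (0.37 log units; beyond the scatter). For compound 4 the estimated value is 30000 nM, with an expected range from 8000 nM to 100000 nM.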

Compound 4, half-maximal inhibitory concentration: > 100000 nM
Compound 4: no number, only a limit; the forecaster's own chance of this, stated with the estimate: 25%; middle value at least 3.3-fold (0.52 log units) away from the limit.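

For the compounds shown here, until now, no two compounds differed in one place only, so nothing showed how much the group on the amide-type nitrogen matters in this assay. With the rest of the molecule unchanged, putting 4-methylbenzyl in place of 3-methoxyphenyl gives an at least 7.8-fold higher number from compound 2 to compound 4 (0.89 log units; beyond the scatter), so this position is sensitive to the change, and the direction is towards weaker inhibition. The step can be read only as a minimum, and its full size stays unknown: the limit of > 100000 nM in this assay, at which 2 of the 4 values shown sit.

The two groups differ in more than one respect, as 4-methylbenzyl has a methyl group where 3-methoxyphenyl has a methoxy group, and its ring is a benzyl rather than a phenyl, so the compounds shown cannot tell which of these differences goes with the weakening. A 4-methylphenyl group or a 3-methoxybenzyl group on the same nitrogen would pull the two differences apart, each changing only one of them relative to compound 2.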